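Cytotoxicity of compound 4 expected from compounds 1 to 3

The compounds below may be only part of what the source reports. "The series", "measured", "known", "first", "only" and "open" are said of these compounds alone.

Three compounds sharing one core were measured in a toxicity assay on HeLa cells (Homo sapiens) for cytotoxicity, read by MTT assay, with a stated time of 24 h; on this read-out higher numbers stand for weaker inhibition and lower numbers for stronger inhibition. Compound 1 `Cc1ncc([N+](=O)[O-])n1CC(O)CSC(=S)N1CCOCC1` gives 4520000 nM in this assay. Compound 2 `Cc1ncc([N+](=O)[O-])n1CC(O)CSC(=S)N1CCCC(C)C1` gives 609000 nM, the step from compound 1 being a 7.4-fold lower number from compound 1 to compound 2 (0.87 log units; beyond the scatter). Compound 3 `Cc1ncc([N+](=O)[O-])n1CC(O)CSC(=S)N(C)C` reaches only a limit of the assay in this assay, > 5000000 nM; this limit is the limit of > 5000000 nM in this assay, at which 1 of the 3 values shown sits. Compound 3 therefore stands at the weak end of the numbers shown, with the step of an at least 8.2-fold higher number from compound 2 to compound 3 (0.91 log units; beyond the scatter) beyond the scatter and the step of an at least 1.1-fold higher number from compound 1 to compound 3 (0.04 log units; that floor lies within the scatter) within it.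

Compound 4 `Cc1ncc([N+](=O)[O-])n1CC(O)CN1CCCC1` is not yet measured. It differs from compound 3 by a group of 5 heavy atoms (4 carbon, 1 nitrogen; one five-membered non-aromatic ring with 1 hetero atom) in place of a group of 6 heavy atoms (3 carbon, 1 nitrogen, 2 sulfur; no ring), on a saturated chain carbon, two bonds along the chain from an oxygen on a saturated carbon. For the measured compounds named here, none of the measured steps changes the same place: all three swap one amine on the thiocarbonyl carbon for another, whereas here the whole group including both sulfur atoms leaves. The measured steps show that amines of different size on that carbon move the number by up to a 7.4-fold lower number from compound 1 to compound 2 (0.87 log units; beyond the scatter), while the dimethylamino compound and the morpholinyl compound sit within the scatter of each other. Going by the values given here, with no step bearing directly on the change, compound 4 is expected to stay near the limit, so the estimated step is an at least 1.2-fold lower number from compound 3 to compound 4 (0.09 log units; that floor lies within the scatter), with a value for compound 4 estimated at 4000000 nM in a range from 1000000 nM to 10000000 nM.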

Compound 4, half-maximal inhibitory concentration: > 5000000 nM
Compound 4 gave a limit, no number; the forecaster's own chance of this, stated with the estimate: 60%; at least 1.2-fold (0.09 log units) between middle value and limit.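

Compound 3 and compound 4 both reach only a limit in this assay, so no step between them can be read: the limit of > 5000000 nM in this assay, at which 2 of the 4 values shown sit.

The compounds shown leave open whether pyrrolidin-1-yl in place of the group carrying both sulfur atoms changes cytotoxicity at all, and by how much, once both compounds have readable numbers.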